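The compounds below may be only part of what the source reports. "The series", "measured", "known", "first", "only" and "open" are said of these compounds alone.

For the measured compounds named here, compound 3 `CN(C)CCCOc1ccc(CN2CC[C@H](NC(=O)c3ccccc3)C2)cc1` is the one member of this small set with a measured number: in an assay on HEK293 cells for binding affinity to Urotensin-2 receptor (Homo sapiens), read by radioligand binding (on this read-out higher numbers stand for weaker inhibition and lower numbers for stronger inhibition), compound 3 gives 2510 nM. Compound 1 `COc1ccc(C(=O)N[C@H]2CCN(Cc3ccc(OCCCN(C)C)cc3)C2)cc1OC` reaches only a limit in this assay, < 10000 nM. Compound 2 `CN(C)CCCOc1ccc(CN2CC[C@H](NC(=O)c3ccc(C#N)cc3)C2)cc1` likewise reaches only a limit in this assay, < 10000 nM. For this reason the steps among the three measured compounds cannot be read in size: a step that the two limits leave unreadable from compound 1 to compound 2, a step that the limit leaves unreadable from compound 1 to compound 3 and a step that the limit leaves unreadable from compound 2 to compound 3 (the limit of < 10000 nM in this assay, at which 2 of the 3 values shown sit).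

Compound 4 `CC(=O)N[C@H]1CCN(Cc2ccc(OCCCN(C)C)cc2)C1` keeps the shared core and its basic side chain but changes the amide: methyl in place of phenyl on a carbonyl carbon, so the benzamido group becomes an acetamido group. Going by the values given here, none of the measured steps touches this position, so no number from the set bears directly on it. Removing the whole aromatic ring from the amide is a larger change than any of the measured ones, and an affinity weaker than that of compound 3 is expected; the step from compound 3 to compound 4 is estimated as a 3.2-fold higher number from compound 3 to compound 4 (0.50 log units; beyond the scatter). Compound 4 is therefore expected to show roughly 8000 nM in this assay, within a range of 1500 nM to 40000 nM, with a real chance that only a limit is reported.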

Compound 4, inhibition constant: < 10000 nM
Compound 4: no number, only a limit; the forecaster's own chance of this, stated with the estimate: 55%; the middle value lies beyond the limit too.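

The steps from compound 1, compound 2 and compound 3 to compound 4 cannot be read in size, because compound 4 also gives only a limit: the limit of < 10000 nM in this assay, at which 3 of the 4 values shown sit.

The compounds shown leave open how far the change from benzamido to acetamido shifts the inhibition constant.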